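Hydroxyphenyl pyridines: ring swap at the third position

This account rests on a few compounds, and the source may have more. Where it says the series, first, only, none or still open, it means among the compounds named here.

In an assay on isolated protein for inhibition of DNA topoisomerase 1 (Homo sapiens), with a stated time of 30 min, tested at 100 uM (a higher number here means a stronger effect of the compound at the concentration tested, a lower number a weaker effect), compound 1 `Oc1cccc(-c2cc(-c3cccs3)cc(-c3ccccc3O)n2)c1` gives 83.2% and compound 2 `Oc1cccc(-c2cc(-c3cccs3)cc(-c3cccc(O)c3)n2)c1` gives 91.7%. The change between them is 3-hydroxyphenyl in place of 2-hydroxyphenyl on an aromatic carbon and the step it made was a number 8.5 percentage points higher from compound 1 to compound 2 (within the scatter). Compound 3 `Oc1cccc(-c2cc(-c3cccnc3)cc(-c3ccccc3O)n2)c1` differs from compound 1 by pyridin-3-yl in place of thiophen-2-yl on an aromatic carbon, and in this assay compound 3 gives 1.9%, a step of a number 81.3 percentage points lower from compound 1 to compound 3 (beyond the scatter). Compound 4 `Oc1cccc(-c2cc(-c3cccnc3)cc(-c3cccc(O)c3)n2)c1` is not yet measured; it differs from compound 3 by 3-hydroxyphenyl in place of 2-hydroxyphenyl on an aromatic carbon. This is the same kind of change as from compound 1 to compound 2, but around the place the neighbour differs: meta to a pyridin-3-yl group here, meta to a thiophen-2-yl group there. Because the earlier step was a number 8.5 percentage points higher from compound 1 to compound 2 (within the scatter), a similarly small step of a number 6.1 percentage points higher from compound 3 to compound 4 (within the scatter) is expected from compound 3 to compound 4. Compound 4 is estimated at 8%, between 0% and 25%.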

Compound 4, a percentage reported as inhibition, at one concentration (the size of the read-out at that concentration, not a potency): 2.1%
Compound 4: middle estimate off by 5.9 percentage points, on the high side, within the range that was stated.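

In this assay, moving from 2-hydroxyphenyl to 3-hydroxyphenyl on the core bearing pyridin-3-yl gives a number 0.2 percentage points higher from compound 3 to compound 4 (within the scatter), and this change carries across the two cores without a measurable difference: the same change on two cores in this assay, a number 8.5 percentage points higher (within the scatter) from compound 1 to compound 2 and a number 0.2 percentage points higher (within the scatter) from compound 3 to compound 4, 8.3 percentage points apart, within the scatter of two such steps

The swap from thiophen-2-yl to pyridin-3-yl also carries across, now with 3-hydroxyphenyl in place, as a number 89.6 percentage points lower from compound 2 to compound 4 (beyond the scatter): the same change on two cores in this assay, a number 81.3 percentage points lower (beyond the scatter) from compound 1 to compound 3 and a number 89.6 percentage points lower (beyond the scatter) from compound 2 to compound 4, 8.3 percentage points apart, within the scatter of two such steps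

Among these compounds, this covers only two cores and a single test concentration, and it does not show that either change would transfer elsewhere; compound 3 and compound 4 both read close to zero, leaving little room to see any fall on that core.

Going by these compounds, a plain phenyl, furan-2-yl or thiophen-3-yl in place of thiophen-2-yl remains open. So does the effect of an amine or a carboxylic acid in place of the hydroxyl groups.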